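Bromo for Chloro on the Phenyl Carbonyl

The source may report more compounds than this note shows. Statements on the series, on what has been measured and on what is new or still open speak of the compounds shown alone.

Compound 1 `CN(C(=O)CCc1ccccc1)c1ccc2[nH]c(-c3n[nH]c4ccccc34)cc2n1`: 11200 nM
Compound 2 `CN(C(=O)c1ccc(Cl)cc1)c1ccc2[nH]c(-c3n[nH]c4ccccc34)cc2n1`: 3000 nM

Of the compounds shown here, two have been measured in a functional assay on HCT-116 cells (Homo sapiens) for antiproliferative activity, read by MTT assay, with a stated time of 72 h; a lower number here means a stronger inhibitor, a higher number a weaker inhibitor. Compound 1, carrying the phenethyl group on the carbonyl carbon, gives 11200 nM. Among the compounds with values here, compound 2, with 4-chlorophenyl in its place, gives 3000 nM, the lowest of the two numbers; the step of a 3.7-fold lower number from compound 1 to compound 2 (0.57 log units; beyond the scatter) lies beyond the scatter and is the only measured step available.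

Compound 3 `CN(C(=O)c1ccc(Br)cc1)c1ccc2[nH]c(-c3n[nH]c4ccccc34)cc2n1` has not yet been measured. It differs from compound 2 by bromo in place of chloro on an aromatic carbon. Within the data shown here, no measured step bears on a change of this kind: the single step from compound 1 to compound 2 exchanged the whole group on the carbonyl carbon, not one halogen for another, so it gives no guidance on direction or size. The expected step of a 1.2-fold lower number from compound 2 to compound 3 (0.08 log units; within the scatter) is therefore taken to stay within the scatter. Compound 3 is expected to give about 2500 nM, with a range from 1100 nM to 6000 nM.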

Compound 3, half-maximal inhibitory concentration: 6110 nM
Compound 3: middle estimate off by 2.4-fold (0.39 log units), on the low side; measured number above the stated range.
By their numbers in this assay, from the lowest: compound 2; then compounds 3 and 1 (each within the scatter of the next).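

In this assay, exchanging one halogen for another on this aromatic carbon, para to a large group, is enough to register: a 2.0-fold higher number from compound 2 to compound 3 (0.31 log units; beyond the scatter) shows that the position does not treat chloro and bromo alike. The gain seen with 4-chlorophenyl in place of phenethyl therefore does not simply carry over to 4-bromophenyl, since a 1.8-fold lower number from compound 1 to compound 3 (0.26 log units; within the scatter) leaves compound 3 and compound 1 unseparated. Nothing available gives a reason for the difference between the two halogens.

With only chloro and bromo at this place, the compounds shown cannot say whether the number follows any trend across substituents such as fluoro, iodo, methoxy or an amine. They also leave open whether hydrogen at this place would fall nearer to compound 2 or to compound 3.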